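The compounds below may be only part of what the source reports. "The series", "measured", "known", "first", "only" and "open" are said of these compounds alone.

Measured compounds:
compound 1 `COc1ccc2c(c1)OC(c1cc(OC)c(OC)c(OC)c1)C(C=O)=C2` — 13500 nM
compound 2 `COc1ccc2c(c1)OC(c1cc(OC)c(OC)c(OC)c1)C(C(=O)OC(C)(C)C)=C2` — 14100 nM
compound 3 `COc1ccc2c(c1)OC(c1cc(OC)c(OC)c(OC)c1)C(C(=O)N(C)C)=C2` — > 50000 nM (a limit)

In a functional assay for inhibition of nuclear factor NF-kappa-B complex (Homo sapiens) (on this read-out lower numbers stand for stronger inhibition and higher numbers for weaker inhibition), compound 1 gives 13500 nM. Compound 2 lies within the scatter of it, the step being a 1.0-fold higher number from compound 1 to compound 2 (0.02 log units; within the scatter). For compound 3 the assay returns only a limit, > 50000 nM. The steps to it, an at least 3.7-fold higher number from compound 1 to compound 3 (0.56 log units; beyond the scatter) and an at least 3.5-fold higher number from compound 2 to compound 3 (0.54 log units; beyond the scatter), run towards weaker inhibition, and their size rests on (the limit of > 50000 nM in this assay, at which 1 of the 3 values shown sits).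

Compound 4 `COc1ccc2c(c1)OC(c1cc(OC)c(OC)c(OC)c1)C(C(C)=O)=C2` awaits measurement in this assay. Its difference from compound 1 is methyl in place of hydrogen on a carbonyl carbon. Both measured steps change the same hydrogen on the carbonyl carbon: tert-butoxy left the number within the scatter, dimethylamino moved it beyond the scatter to weaker inhibition. Methyl is the smallest of the three entering groups, so the step of a 1.2-fold higher number from compound 1 to compound 4 (0.07 log units; within the scatter) is expected to stay within the scatter, with the weaker-inhibition direction the more likely should it exceed it. Compound 4 is therefore estimated at 16000 nM, between 7000 nM and 36000 nM.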

Compound 4, half-maximal inhibitory concentration: 14100 nM
Compound 4: middle estimate off by 1.1-fold (0.05 log units), on the high side; low and high end bracket the measured number.
By their numbers in this assay, from the lowest: compounds 1, 2 and 4 (each within the scatter of the next). At a limit, above all of these: compound 3.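

In this assay, the carbonyl carbon on the double-bonded ring carbon now also carries methyl, and formyl to acetyl reads a 1.0-fold higher number from compound 1 to compound 4 (0.02 log units; within the scatter). Methyl in place of tert-butoxy reads no change at the digits printed from compound 2 to compound 4 (within the scatter), so compounds with hydrogen, methyl and tert-butoxy on this carbonyl carbon cannot be told apart in this assay. Dimethylamino remains the only entering group among these that separates from the others, with an at least 3.5-fold lower number from compound 3 to compound 4 (0.54 log units; beyond the scatter), and the size of that step rests on a limit of the assay: the limit of > 50000 nM in this assay, at which 1 of the 4 values shown sits.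

Open, going by these compounds, is whether a longer chain such as ethyl, a carboxylic acid or a primary amide on this carbonyl carbon would stay with compounds 1, 2 and 4 or move as dimethylamino does. Also open, on these data alone, is how far the true number of compound 3 lies from its limit.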